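The source may hold more compounds than are shown below. What is called first, only, known or untested is meant among the compounds shown, and "the series" means these compounds.

Measured compounds in this series:

compound 1, `Cn1c(CN2CCC(c3ccc(Cl)cc3)CC2)nc2ccccc21`: 79.4 nM
compound 2, `CCCn1c(CN2CCN(c3nc(Cl)ccc3C(F)(F)F)CC2)nc2ccccc21`: 2510 nM

For the measured compounds named here, in an assay on CHO cells with metabotropic glutamate receptor 2 (Homo sapiens) as the target, read by FLIPR (a higher number here means that more compound is needed for the effect, a lower number that less compound is needed), compound 2 gives 2510 nM, the highest number of the two measured so far. Its nearest neighbour is compound 1, which in this assay gives 79.4 nM; that gap lies beyond the scatter, and nothing more than the two values themselves is known about it, since the two compounds differ in several places at once.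

Compound 3, `COCCn1c(CN2CCN(c3nc(Cl)ccc3C(F)(F)F)CC2)nc2ccccc21`, is the next point. It differs from compound 2 in one place only: methoxy in place of methyl on a saturated chain carbon, two bonds along the chain from an aromatic nitrogen. Going by the values given here, no step of this kind between two measured compounds exists, so there is no direct precedent for its size. The change is confined to the chain on the aromatic nitrogen and leaves the rest of compound 2 untouched, so the expectation is a step in this assay of no more than the usual scatter, with no firm direction. For compound 3 the estimated step from compound 2 is a 1.0-fold lower number from compound 2 to compound 3 (0.00 log units; within the scatter). The expected value for compound 3 in this assay is therefore 2500 nM, with a range from 800 nM to 8000 nM.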

Compound 3, half-maximal effective concentration: 158 nM
For compound 3 the middle estimate is 16-fold (1.20 log units) above the measured one, outside the stated range (below it).
By their numbers in this assay, from the lowest: compounds 1 and 3 (each within the scatter of the next); then compound 2.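

In this assay, for the compounds shown here, the chain on the aromatic nitrogen proves to be a place where one change can move the number: methoxy in place of methyl on a saturated chain carbon, two bonds along the chain from an aromatic nitrogen, gives a 16-fold lower number from compound 2 to compound 3 (1.20 log units; beyond the scatter) in the first step that can be read in one place. With the rest of compound 2 untouched, the change from propyl to 2-methoxyethyl is enough on its own to go beyond the scatter, towards less compound being needed for the effect. Methoxy brings 1 hydrogen-bond acceptor where methyl brings 0, but no measurement available here connects the step to that count or to any other feature of the group.

From the compounds shown here alone, whether the step depends on the oxygen itself or on where it sits in the chain stays open; a 2-hydroxyethyl chain, a 3-methoxypropyl chain or a butyl chain would help separate the two. Also open, going by these compounds, are what an amine at the end of the chain would do and whether 2-methoxyethyl has a similar effect on the core of compound 1.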